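Quinolinyl and indolyl amines on the shared core

The source may report more compounds than this note shows. Statements on the series, on what has been measured and on what is new or still open speak of the compounds shown alone.

Compound 1 `Cc1ccc(S(=O)(=O)c2cc3cnc(Nc4cccc5cccnc45)nc3n(C)c2=O)cc1` gives 10000 nM in a functional assay on K562 cells (Homo sapiens) for inhibition, read by trypan blue exclusion, with a stated time of 72 h; on this read-out higher numbers stand for weaker inhibition and lower numbers for stronger inhibition. Compound 2 `Cc1ccc(S(=O)(=O)c2cc3cnc(Nc4ccc5cc[nH]c5c4)nc3n(C)c2=O)cc1` gives 15000 nM, and compound 3 `Cc1ccc(S(=O)(=O)c2cc3cnc(Nc4cnc5[nH]ccc5c4)nc3n(C)c2=O)cc1` gives 15000 nM in this assay; compound 3 thus sits level with compound 2, and both are the highest of the three numbers, with compound 1 the nearest lower number. Compound 4 `Cc1ccc(S(=O)(=O)c2cc3cnc(Nc4ccc5ncccc5c4)nc3n(C)c2=O)cc1` differs from compound 3 by a group of 10 heavy atoms (9 carbon, 1 nitrogen; one six-membered aromatic ring of carbon only, one six-membered aromatic ring with 1 hetero atom) in place of a group of 9 heavy atoms (7 carbon, 2 nitrogen; one five-membered aromatic ring with 1 hetero atom, one six-membered aromatic ring with 1 hetero atom), on a nitrogen on an aromatic ring. Within the data shown here, the steps that bear on this are a 1.5-fold higher number from compound 1 to compound 3 (0.18 log units; within the scatter) and no change at the digits printed from compound 2 to compound 3 (within the scatter), both within the scatter, so the bicyclic amine swaps so far move this assay little. For compound 4 a step of a 1.3-fold lower number from compound 3 to compound 4 (0.10 log units; within the scatter) is therefore expected, within the scatter, and the estimated value is 12000 nM with a range of 5000 nM to 30000 nM.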

Compound 4, half-maximal inhibitory concentration: 10000 nM
Estimate against measurement, compound 4: 1.2-fold (0.08 log units) above; the measured number falls inside the stated range.
By their numbers in this assay, from the lowest: compounds 1, 4, 2 and 3 (each within the scatter of the next).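

With quinolin-6-yl on the nitrogen, this assay gives a 1.5-fold lower number from compound 3 to compound 4 (0.18 log units; within the scatter) and a 1.5-fold lower number from compound 2 to compound 4 (0.18 log units; within the scatter) as well, even though this group carries 0 hydrogen-bond donors and the group it replaces in compound 3 carries 1. Against quinolin-8-yl, the swap gives no change at the digits printed from compound 1 to compound 4 (within the scatter) and so separates the two quinolinyl amines no further. No supporting evidence on these steps is available, so the flat read-out stays without explanation.

Still open, going by these compounds, is whether a quinolin-6-yl bearing an amine or a carboxylic acid, or a plain phenyl on the nitrogen, would move the number beyond the scatter.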